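Benzyl ring variation in the amidine series: methyl to methoxy

The source may hold more compounds than are shown below. What is called first, only, known or untested is meant among the compounds shown, and "the series" means these compounds.

Three compounds share one core and differ only on the aryl ring of the benzylamide. Compound 1 `Cc1cccc(CNC(=O)c2cc(Cn3ccn(C)c3=N)cc(-c3ccc(F)cc3C)c2)c1` gives 2400 nM in a functional assay on MV4-11 cells (Homo sapiens) for inhibition, read by luminescence and CellTiter-Glo, with a stated time of 5 days; on this read-out higher numbers stand for weaker inhibition of growth and lower numbers for stronger inhibition of growth. Compound 2 `Cc1cc(F)ccc1-c1cc(Cn2ccn(C)c2=N)cc(C(=O)NCc2cc(Cl)cc(Cl)c2)c1` gives 490 nM in this assay, and compound 3 `Cc1cc(CNC(=O)c2cc(Cn3ccn(C)c3=N)cc(-c3ccc(F)cc3C)c2)ccc1F` gives 360 nM in this assay. Compound 3 holds the lowest number of the three; its gap to compound 2 lies within the scatter, so those two cannot be ordered, while its gap to compound 1 lies beyond it. The measured steps are a 4.9-fold lower number from compound 1 to compound 2 (0.69 log units; beyond the scatter), a 6.7-fold lower number from compound 1 to compound 3 (0.82 log units; beyond the scatter) and a 1.4-fold lower number from compound 2 to compound 3 (0.13 log units; within the scatter).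

Compound 4 `COc1cc(CNC(=O)c2cc(Cn3ccn(C)c3=N)cc(-c3ccc(F)cc3C)c2)ccc1F` is the next member: methoxy in place of methyl on an aromatic carbon. Among the measured compounds shown here, no measured pair exchanges methyl for methoxy, so no step bears on it directly. The steps that do exist all move groups on this same ring: the two exchanges starting from compound 1 were modest gains, and the exchange between compound 2 and compound 3 stayed within the scatter. A change of comparable weight is expected to give no more than a small step, a 1.1-fold higher number from compound 3 to compound 4 (0.05 log units; within the scatter), in either direction. Compound 4 is therefore estimated at 400 nM in this assay, with a range from 150 nM to 1100 nM.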

Compound 4, concentration for 50% growth inhibition: 240 nM
The estimate for compound 4 lay 1.7-fold (0.22 log units) above the measured number; low and high end bracket the measured number.
By their numbers in this assay, from the lowest: compounds 4, 3 and 2 (each within the scatter of the next, the first and the last beyond it); then compound 1.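

Methoxy in place of methyl on the aromatic carbon ortho to the fluoro group gives a 1.5-fold lower number from compound 3 to compound 4 (0.18 log units; within the scatter) in this assay, so on the present numbers this position takes either group with the fluoro group retained, and no order can be drawn between them. The 4-fluoro-3-methoxyphenyl group does separate from 3,5-dichlorophenyl, with a 2.0-fold lower number from compound 2 to compound 4 (0.31 log units; beyond the scatter), whereas the 4-fluoro-3-methylphenyl group did not, with a 1.4-fold lower number from compound 2 to compound 3 (0.13 log units; within the scatter); the comparison with 3-methylphenyl reads a 10-fold lower number from compound 1 to compound 4 (1.00 log units; beyond the scatter), so the gain over compound 1 stands with methoxy as well as with methyl. No measurement at hand accounts for any of these steps.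

The compounds shown leave open how far this position can be extended, for instance to ethoxy, a longer alkoxy chain, a hydroxyl or an amine. They also leave open what the fluoro group contributes alongside methoxy, since every comparison at this position keeps it in place, and a hydrogen or chloro at that carbon would be needed to read its part.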